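The source may hold more compounds than are shown below. What is called first, only, known or untested is meant among the compounds shown, and "the series" means these compounds.

Series notes. Compound 1 `C/C(=N\NC(=O)c1ccncc1)C(=O)Nc1ccc(OC(F)(F)F)cc1` is the point of reference. In an ADME assay on HepG2 cells (Homo sapiens) for cytotoxicity, read by MTT assay (a lower number here means a stronger inhibitor, a higher number a weaker inhibitor), compound 1 gives only a limit, > 50000 nM. Compound 2 `C/C(=N\NC(=O)c1ccncc1)C(=O)Nc1ccc(Cl)c(Cl)c1` in this assay likewise reaches only a limit, > 50000 nM. Compound 3 `C/C(=N\NC(=O)c1ccncc1)C(=O)Nc1cc(Cl)cc(Cl)c1` in this assay also sits at a limit, > 50000 nM. Going by the values given here, compound 1 thus stands together with the other two at the limit of > 50000 nM in this assay, at which 3 of the 3 values shown sit, and no measured step separates any pair. Compound 4 `C/C(=N\NC(=O)c1ccncc1)C(=O)Nc1ccc(Br)cc1` remains to be measured in this assay; it differs from compound 1 by bromo in place of trifluoromethoxy on an aromatic carbon. With every measured value resting at the limit, no step beyond the scatter is expected in this assay in either direction. The step expected in this assay is a number no higher from compound 1 to compound 4 (the limit leaves the size open), effectively none. Compound 4 is estimated at 50000 nM, within 25000 nM to 100000 nM, and will most likely again be reported only as a limit.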

Compound 4, half-maximal inhibitory concentration: > 50000 nM
Compound 4 ended at the assay's limit; the forecaster's own chance of this, stated with the estimate: 85%; the middle value sits exactly at the limit.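

Compound 1 and compound 4 both rest at a limit, so no step between them can be read in this assay: the limit of > 50000 nM in this assay, at which 4 of the 4 values shown sit.

The compounds shown leave open whether any real difference separates them in this assay, and whether any substituent on the shared core would lower the value.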